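Two aryl piperazines and a planned fluoro analog

A few compounds are considered here, and "the series" means these few. Any claim that something is new, unique, unknown or untested is made for them only; others in the source may bear on it.

Compound 1 `Cc1cccc(N2CCN(C(=O)CN3C(=O)CC(C)(c4ccccc4)C3=O)CC2)c1`: "not active" (no number reported)
Compound 2 `CC1(c2ccccc2)CC(=O)N(CC(=O)N2CCN(c3ccccc3Cl)CC2)C1=O`: 100 mg/kg

Compound 1 `Cc1cccc(N2CCN(C(=O)CN3C(=O)CC(C)(c4ccccc4)C3=O)CC2)c1` is recorded in a functional assay on the whole organism (strain CD-1) with Mus musculus as the target, with a stated time of 2 h (a lower number here means that less compound is needed, a higher number that more compound is needed for the effect), as "not active" (no number reported), so no number is available for it. Within the data shown here, compound 2 `CC1(c2ccccc2)CC(=O)N(CC(=O)N2CCN(c3ccccc3Cl)CC2)C1=O` is the only member of the pair with a number: in this assay compound 2 gives 100 mg/kg. Among the measured compounds shown here, nothing else in the set has a value, so compound 2 stands alone as the single reference point, and no step between measured compounds can be computed.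

Compound 3 `CC1(c2ccccc2)CC(=O)N(CC(=O)N2CCN(c3ccc(F)cc3)CC2)C1=O` has not yet been tested in this assay. It differs from compound 2 in one place: 4-fluorophenyl in place of 2-chlorophenyl on an amine nitrogen in a ring. The remainder of the molecule, the shared core carrying the substituted piperazine amide, is unchanged.

For the measured compounds named here, with no measured step available, the expectation for compound 3 rests on compound 2 alone, whose value 100 mg/kg serves as the anchor. The change from compound 2 to compound 3 is expected to give a step of about no change at the digits printed from compound 2 to compound 3 (within the scatter), which means no shift beyond the usual scatter in either direction. Compound 3 is therefore estimated at 100 mg/kg, with a plausible range from 30 mg/kg to 300 mg/kg.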

Compound 3, minimum effective dose: "not active" (no number reported)
Nothing numeric was reported for compound 3; no gap can be computed for the estimate.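

Among these compounds, compound 3 is recorded in this assay as "not active" (no number reported) and so gives no step from compound 2, whose 100 mg/kg remains the only number. No evidence here bears on this result. The compounds shown leave open how any aryl group other than 2-chlorophenyl would compare numerically with compound 2.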